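An acetyl group on the amino nitrogen of compound 2

The source may hold more compounds than are shown below. What is called first, only, known or untested is meant among the compounds shown, and "the series" means these compounds.

Compound 1 (`CC(=O)Nc1n[nH]c2cc(-c3cn([C@@H]4CN[C@H](C(=O)Nc5ccc(Cl)c(C(F)(F)F)c5)C4)nn3)ccc12`) gives 15500 nM 
Compound 2 (`Nc1n[nH]c2cc(-c3cn([C@@H]4CN[C@H](C(=O)Nc5ccc(Cl)cc5Cl)C4)nn3)ccc12`) gives 28400 nM 

In a functional assay on K562 cells (Homo sapiens) for inhibition, read by MTT assay, with a stated time of 48 h (a lower number here means a stronger inhibitor, a higher number a weaker inhibitor), compound 2 (28400 nM) lies within the usual scatter of compound 1, so neither can be ranked above the other. The next compound, compound 3 (`CC(=O)Nc1n[nH]c2cc(-c3cn([C@@H]4CN[C@H](C(=O)Nc5ccc(Cl)cc5Cl)C4)nn3)ccc12`), keeps the rest of compound 2 and has acetyl in place of hydrogen on a nitrogen on an aromatic ring, which turns amino to acetamido (acetyl in place of hydrogen on a nitrogen on an aromatic ring). Among the measured compounds shown here, no measured pair shows this change alone. The acetamido group already stands on compound 1, which differs elsewhere as well, and compound 1 (15500 nM) stays within the scatter of compound 2. On this thin evidence, no change beyond the scatter is expected in this assay for this step. The estimated step (a 1.4-fold lower number from compound 2 to compound 3 (0.15 log units; within the scatter)) is therefore small. Compound 3 is expected at 20000 nM with an estimated range (8000 nM to 50000 nM).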

Compound 3, half-maximal inhibitory concentration: 2090 nM
For compound 3 the middle estimate is 9.6-fold (0.98 log units) above the measured one, outside the stated range (below it).
By their numbers in this assay, from the lowest: compound 3; then compounds 1 and 2 (each within the scatter of the next).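

In this assay, the nitrogen carrying the amino group proves to be a position where a single change counts: acetyl in place of hydrogen there gives a 14-fold lower number from compound 2 to compound 3 (1.13 log units; beyond the scatter). With the acetamido group held in place, 2,4-dichlorophenyl in place of 4-chloro-3-(trifluoromethyl)phenyl on an amide-type nitrogen gives a 7.4-fold lower number from compound 1 to compound 3 (0.87 log units; beyond the scatter), so this group matters as well, which compound 1 and compound 2 could not show, as they differ in two places. Nothing measured here explains either step.

As far as these compounds go, whether the gain needs acetyl itself, or would also come with a propionyl, a methanesulfonyl or a simple methyl group on that nitrogen, remains open. Also open, from the compounds shown here alone, is whether the step between the two aryl groups would hold with the free amino group in place of acetamido.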